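Swapping the 4-fluorophenyl of compound 1 for 2,4-dichlorophenyl

The source may report more compounds than this note shows. Statements on the series, on what has been measured and on what is new or still open speak of the compounds shown alone.

Measured compounds:
compound 1, `CCOC(=O)c1sc(-c2ccccc2)nc1N1CCC(NCc2ccc(F)cc2)CC1`: 6.23%
compound 2, `CCOC(=O)c1sc(-c2ccccc2)nc1N1CCC(NCc2ccc(OCc3ccccc3)cc2)CC1`: 18.4%

In an ADME assay on RAW264.7 cells (Mus musculus) for cytotoxicity, read by MTT assay, with a stated time of 72 h, tested at 50 uM (a lower number here means less inhibition, a higher number more inhibition at the concentration tested (going by the name of the read-out)), compound 1 gives 6.23%, the lowest of the two numbers at hand. For the measured compounds named here, its nearest neighbour is compound 2, which in this assay gives 18.4%; the only measured step, a number 12.2 percentage points higher from compound 1 to compound 2 (beyond the scatter), is a modest rise that lies beyond the scatter.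

Compound 3, `CCOC(=O)c1sc(-c2ccccc2)nc1N1CCC(NCc2ccc(Cl)cc2Cl)CC1`, has not been measured in this assay. It differs from compound 1 in one place: 2,4-dichlorophenyl in place of 4-fluorophenyl on a saturated chain carbon bound to an amine nitrogen. The step from compound 1 to compound 2 is the only one that bears on this change, since it also swaps the substituent on that same aromatic ring, and it moved the number modestly upward. The present change is of a different kind, so the direction for compound 3 is uncertain; a modest change is expected, most likely upward, in line with the rise seen from compound 1 to compound 2 in a number 12.2 percentage points higher from compound 1 to compound 2 (beyond the scatter). For compound 3 the expected step is a number 7.8 percentage points higher from compound 1 to compound 3 (within the scatter). Compound 3 is estimated to give 14% in this assay, within a range from 2% to 30%.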

Compound 3, a percentage reported as inhibition, at one concentration (the size of the read-out at that concentration, not a potency): 9.43%
The estimate for compound 3 lay 4.6 percentage points above the measured number; the measured number falls inside the stated range.
By their numbers in this assay, from the lowest: compounds 1, 3 and 2 (each within the scatter of the next, the first and the last beyond it).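

With 2,4-dichlorophenyl in place of 4-fluorophenyl on a saturated chain carbon bound to an amine nitrogen, this assay gives a number 3.2 percentage points higher from compound 1 to compound 3 (within the scatter) and so does not separate the two compounds. The earlier compounds shown here showed only that this position can respond, with a number 12.2 percentage points higher from compound 1 to compound 2 (beyond the scatter) for benzyloxy in place of fluoro on the aromatic ring; compound 3 shows that not every replacement there moves the number beyond the scatter, as the exchange of one fluorine for two chlorines on that ring leaves compound 3 at 9.43% in this assay. For the compounds shown here, of the two replacements on this ring, only the one carrying benzyloxy gives a step beyond the scatter, and nothing available accounts for this difference.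

Going by these compounds alone, with only three compounds, these results do not show how the read-out would respond to an amine or a carboxylic acid on this aromatic ring, or to a longer chain joining that ring to the amine nitrogen. They also leave open whether the same small range would hold if the ethyl ester of the shared core gave way to a carboxylic acid or an amide.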